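Swapping cyano for benzyloxycarbonyl on compound 3

The source may hold more compounds than are shown below. What is called first, only, known or untested is meant among the compounds shown, and "the series" means these compounds.

Compound 1 `COc1ccc(-c2cc3c(OC)cc(OC)cc3n(CC#N)c2=O)cc1`: 10000 nM
Compound 2 `COC(=O)CCn1c(=O)c(-c2ccc(OC)cc2)cc2c(OC)cc(OC)cc21`: 10000 nM
Compound 3 `COc1ccc(-c2cc3c(OC)cc(OC)cc3n(CCC#N)c2=O)cc1`: 10000 nM

In a functional assay on A 172 cells (Homo sapiens) for cytotoxicity, read by colorimetric assay and MTT assay (on this read-out lower numbers stand for stronger inhibition and higher numbers for weaker inhibition), compound 1 and compound 2 stand level with compound 3 at 10000 nM. Compound 4 `COc1ccc(-c2cc3c(OC)cc(OC)cc3n(CCC(=O)OCc3ccccc3)c2=O)cc1` carries benzyloxycarbonyl in place of cyano on a saturated chain carbon, two bonds along the chain from an aromatic nitrogen. The closest measured change, at the same place, is no change at the digits printed from compound 2 to compound 3 (within the scatter). The other two changes on this chain, no change at the digits printed from compound 1 to compound 3 (within the scatter) and no change at the digits printed from compound 1 to compound 2 (within the scatter), show the same picture. Among the measured compounds shown here, the entering group holds a ring that no measured compound carries at this place, so the range stays wide. The expected result is no change at the digits printed from compound 3 to compound 4 (within the scatter), with no shift beyond the scatter in either direction. The estimated value for compound 4 is 10000 nM, with an expected range of 3000 nM to 20000 nM.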

Compound 4, half-maximal inhibitory concentration: 10000 nM
For compound 4 middle estimate and measured number coincide at the digits printed; low and high end bracket the measured number.
By their numbers in this assay, from the lowest: compounds 1, 2, 3 and 4 (each within the scatter of the next).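

In this assay, among the compounds shown here, benzyloxycarbonyl in place of cyano gives no change at the digits printed from compound 3 to compound 4 (within the scatter) even though a six-membered aromatic ring enters this chain for the first time. Phenyl in place of hydrogen on a saturated chain carbon bound to an oxygen next to a carbonyl group likewise gives no change at the digits printed from compound 2 to compound 4 (within the scatter) and (benzyloxycarbonyl)methyl in place of cyano gives no change at the digits printed from compound 1 to compound 4 (within the scatter), so size and the added ring leave the number level here. Nothing available explains this flat picture.

On these data alone, whether any group at this place can move the number stays open, since all four compounds sit level. A carboxylic acid or an amine at the end of this chain might answer that.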